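The compounds below may be only part of what the source reports. "The series", "measured", "known", "first", "only" and "open" are said of these compounds alone.

Compound 1 `O=C(O)CCCCCOc1cc(-c2ccccc2)c2ccccc2n1` and compound 2 `CC(C)(CCCCOc1cc(-c2ccc(C(F)(F)F)cc2)c2ccccc2n1)C(=O)O` differ from each other in more than one place, so no single change separates them. In an assay on membranes from spleen (Cavia porcellus) for binding affinity to leukotriene B4 receptor 1 (Homo sapiens) (a lower number here means a stronger inhibitor, a higher number a weaker inhibitor), compound 1 gives 700 nM, and in this assay compound 2 gives 300 nM. Of the two numbers shown so far, that of compound 2 is the lower one, and its gap to compound 1 lies beyond the usual scatter of this kind of measurement. Compound 3 `CC(C)(CCCCOc1cc(-c2ccc(Cl)cc2)c2ccccc2n1)C(=O)O` has not yet been measured. It differs from compound 2 in one place only: chloro in place of trifluoromethyl on an aromatic carbon. Among the compounds with values here, no pair of measured compounds shows this change, so the data give no step from which its size or direction could be read. The expectation for compound 3 is therefore a step of a 1.2-fold higher number from compound 2 to compound 3 (0.07 log units; within the scatter) that stays within the scatter, in either direction. Compound 3 is estimated at 350 nM in this assay, with a range from 120 nM to 1000 nM.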

Compound 3, half-maximal inhibitory concentration: 15 nM
Estimate against measurement, compound 3: 23-fold (1.37 log units) above; the whole stated range lies above it.
By their numbers in this assay, from the lowest: compound 3; then compound 2; then compound 1.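

In this assay, within the data shown here, the change from trifluoromethyl to chloro, on an aromatic carbon para to a large group, gives a 20-fold lower number from compound 2 to compound 3 (1.30 log units; beyond the scatter) and so stands as the first single change that can be read. It shows that the number is highly sensitive to the group at this position: the step is large and lies beyond the usual scatter, although the exchange only replaces a group of 4 heavy atoms with one of 1 heavy atom, with no hydrogen-bond donor, hydrogen-bond acceptor, ring or net charge on either side. Among these compounds, nothing available explains why this one exchange moves the number so far.

The compounds shown leave open how other groups at the same position would compare with chloro and trifluoromethyl, among them hydrogen, fluoro, bromo, methyl, methoxy or a nitrile. They also leave open whether the same exchange would produce a step of similar size and direction on the side chain of compound 1, which lacks the two methyl groups carried by compound 2 and compound 3.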